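Oxazole-indole pair: methyl to vinyl on the core

The source may hold more compounds than are shown below. What is called first, only, known or untested is meant among the compounds shown, and "the series" means these compounds.

Measured so far:
Compound 1 `Cc1nc(-c2c[nH]c3ccccc23)co1` — 103000 nM
Compound 2 `Clc1ccc(-c2nc(-c3c[nH]c4ccccc34)co2)cc1` — 608000 nM

In a functional assay on MDA-MB-231 cells (Homo sapiens) for cytotoxicity, read by MTT assay, with a stated time of 48 h (a higher number here means a weaker inhibitor, a lower number a stronger inhibitor), compound 1 gives 103000 nM and is the lower of the two numbers; compound 2 gives 608000 nM. Among the compounds with values here, the only measured step, a 5.9-fold higher number from compound 1 to compound 2 (0.77 log units; beyond the scatter), exchanged the methyl for a far larger group. Compound 3 `C=Cc1nc(-c2c[nH]c3ccccc23)co1` differs from compound 1 by vinyl in place of methyl on an aromatic carbon, a change of one carbon with no ring, donor or acceptor added. Within the data shown here, no measured step matches it; the one measured step bears on it only loosely, as it shows that growth at this position did not lower the number. No step beyond the scatter is expected. Compound 3 is estimated at 110000 nM, range 50000 nM to 260000 nM, i.e. an expected 1.1-fold higher number from compound 1 to compound 3 (0.03 log units; within the scatter).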

Compound 3, half-maximal inhibitory concentration: 103000 nM
Estimate against measurement, compound 3: 1.1-fold (0.03 log units) above; the measured number falls inside the stated range.
By their numbers in this assay, from the lowest: compounds 1 and 3 (each within the scatter of the next); then compound 2.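

At this position on the shared core, in this assay, exchanging methyl for vinyl, with its double bond outside aromatic rings, leaves the reading in place: no change at the digits printed from compound 1 to compound 3 (within the scatter). The higher number seen with 4-chlorophenyl therefore does not extend to vinyl, as shown by a 5.9-fold lower number from compound 2 to compound 3 (0.77 log units; beyond the scatter). No measurement shown bears on the reason for either step. Still open, from the compounds shown here alone, is whether an amine, a carboxylic acid or a longer chain here would shift the number, and whether any group would lower it beyond the scatter from compound 1.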